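This account rests on a few compounds, and the source may have more. Where it says the series, first, only, none or still open, it means among the compounds named here.

Measured compounds:
- compound 1 `Cc1cc(C(=O)O)ccc1C(C)N1CCC[C@H](O[C@H](CO)c2cc(Cl)cc(Cl)c2)[C@@H]1c1ccccc1`: "nd" (no result reported)
- compound 2 `Cc1cc(C(=O)O)ccc1CN1CCC[C@H](O[C@H](CO)c2cc(Cl)cc(Cl)c2)[C@@H]1c1ccc(F)cc1`: "nd" (no result reported)
- compound 3 `Cc1cc(C(=O)O)ccc1CN1CCC[C@H](O[C@H](CO)c2cc(Cl)nc(Cl)c2)[C@@H]1c1ccccc1`: > 200000 nM

In an assay on isolated protein for activation of cGMP-dependent protein kinase 1 (Homo sapiens), read by ADP-Glo, with stated times of 30 min and 2 h (on this read-out higher numbers stand for an effect only at larger amounts of compound and lower numbers for an effect already at smaller amounts), compound 1 gives "nd" (no result reported), so no number is known for it. Compound 2 likewise gives "nd" (no result reported) in this assay. Compound 3 gives > 200000 nM in this assay, which is a limit and not a number. For the measured compounds named here, compound 1 therefore stands without a value of its own; the only value among the three with any content is the limit of > 200000 nM in this assay, at which 1 of the 3 values shown sits.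

Compound 4 `COC(=O)c1ccc(CN2CCC[C@H](O[C@H](CO)c3cc(Cl)cc(Cl)c3)[C@@H]2c2ccccc2)c(C)c1` differs from compound 1 as follows: a group of 12 heavy atoms (10 carbon, 2 oxygen; one six-membered aromatic ring of carbon only) in place of a group of 12 heavy atoms (10 carbon, 2 oxygen; one six-membered aromatic ring of carbon only), on an amine nitrogen in a ring. Going by the values given here, no measured step between compounds exists, so the size of this step in this assay cannot be taken from the data; any expectation rests on compound 3 alone. Compound 4 is expected to give about 150000 nM in this assay, estimated between 20000 nM and 400000 nM.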

Compound 4, half-maximal effective concentration: > 200000 nM
Compound 4 was reported as a limit (the forecaster's own chance of this, stated with the estimate: 60%); middle value at least 1.3-fold (0.12 log units) away from the limit.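

In this assay compound 4 gives > 200000 nM, a limit and not a number. No step can be read between compound 4 and compound 1 or compound 3. From the compounds shown here alone, what the change on the amine nitrogen does in this assay stays open.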